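The source may report more compounds than this note shows. Statements on the series, on what has been measured and on what is new or still open speak of the compounds shown alone.

Compound 1 `C[C@H](NC(=O)C(=O)Nc1cccnc1N(C)C)C(=O)N[C@@H](CC(=O)O)C(=O)COc1c(F)c(F)cc(F)c1F` is measured in a functional assay on Jurkat cells (Homo sapiens) (on this read-out lower numbers stand for stronger inhibition and higher numbers for weaker inhibition), where compound 1 gives 27 nM. Two measured neighbours differ from it only in the group on the amide-type nitrogen. Compound 3 `C[C@H](NC(=O)C(=O)NCc1cc(Cl)cc(Cl)c1)C(=O)N[C@@H](CC(=O)O)C(=O)COc1c(F)c(F)cc(F)c1F` carries 3,5-dichlorobenzyl there and gives 23 nM; the step of a 1.2-fold lower number from compound 1 to compound 3 (0.07 log units; within the scatter) lies within the scatter, so compound 1 and compound 3 stand together. Compound 2 `Cc1ccc(CNC(=O)C(=O)N[C@@H](C)C(=O)N[C@@H](CC(=O)O)C(=O)COc2c(F)c(F)cc(F)c2F)cc1C` carries 3,4-dimethylbenzyl and is reported only as a limit of this assay, > 10000 nM. The step of an at least 370-fold higher number from compound 1 to compound 2 (2.56 log units; beyond the scatter) is large, as is an at least 430-fold lower number from compound 2 to compound 3 (2.63 log units; beyond the scatter). Compound 4 `C[C@H](NC(=O)C(=O)NCc1cc(F)cc(F)c1)C(=O)N[C@@H](CC(=O)O)C(=O)COc1c(F)c(F)cc(F)c1F` is not yet measured; it differs from compound 1 by 3,5-difluorobenzyl in place of 2-(dimethylamino)pyridin-3-yl on an amide-type nitrogen. The step to compound 3 is the closest guide, with a dihalogenated benzyl group entering in the same place, and it was within the scatter; the step to compound 2 shows that a benzyl group there can also lose nearly all activity. For compound 4 the expected step is a 1.5-fold higher number from compound 1 to compound 4 (0.17 log units; within the scatter), within the scatter or at most slightly weaker. Compound 4 is therefore estimated at 40 nM, with a range from 12 nM to 150 nM.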

Compound 4, half-maximal inhibitory concentration: 16 nM
Beside the measured number, compound 4's estimate is 2.5-fold (0.40 log units) above it; measured number inside the range.
By their numbers in this assay, from the lowest: compounds 4, 3 and 1 (each within the scatter of the next). At a limit, above all of these: compound 2.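

In this assay, a second dihalogenated benzyl group matches the 2-(dimethylamino)pyridin-3-yl group on the amide-type nitrogen, with a 1.7-fold lower number from compound 1 to compound 4 (0.23 log units; within the scatter). Fluorine and chlorine on the 3,5-disubstituted ring cannot be told apart here, with a 1.4-fold lower number from compound 3 to compound 4 (0.16 log units; within the scatter), so compound 3 was not a lone case among the benzyl compounds. The 3,5-difluorobenzyl group also stands far from the 3,4-dimethylbenzyl group, with an at least 620-fold lower number from compound 2 to compound 4 (2.79 log units; beyond the scatter), which shows that compound 2 is set apart from two halogenated benzyl compounds, not just one.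

From the compounds shown here alone, how far compound 2 really lies from the others stays open, since its value is only a limit: the limit of > 10000 nM in this assay, at which 1 of the 4 values shown sits. Also open is whether its loss of activity follows the methyl groups or where they sit, a question that 3,5-dimethylbenzyl and 3,4-dichlorobenzyl groups would address.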